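The source may hold more compounds than are shown below. What is called first, only, known or untested is meant among the compounds shown, and "the series" means these compounds.

Working notes on the series. Within the data shown here, in a physicochemical assay for lipophilicity, read by HPLC (on this read-out lower numbers stand for lower lipophilicity and higher numbers for higher lipophilicity), compound 1 (`CC(C)C[C@@H]1C(=O)N[C@H](C2Cc3ccccc3C2)C(=O)N1[C@@H](C(=O)N(C)C)c1ccc(N(C)C)nc1`) gives 2.6 and compound 2 (`COc1ccc([C@H](C(=O)N2CCOCC2)N2C(=O)[C@@H](C3Cc4ccccc4C3)NC(=O)[C@H]2CC(C)C)cn1`) gives 2.7, so compound 2 stands within the scatter of the only other number available. Compound 3 (`COc1ccc([C@H](C(=O)N(C)C)N2C(=O)[C@@H](C3Cc4ccccc4C3)NC(=O)[C@H]2CC(C)C)cn1`) differs from compound 2 in one place (dimethylamino in place of morpholin-4-yl on a carbonyl carbon), with dimethylamino in place of morpholin-4-yl on a carbonyl carbon. Among the measured compounds shown here, no measured pair shows this change on its own, so the guide is thin. Compound 1 also bears dimethylamino on a carbonyl carbon, yet its 2.6 lies within the scatter of compound 2 at 2.7. No step beyond the scatter is therefore expected in this assay, in either direction. The estimated step of no change at the digits printed from compound 2 to compound 3 (within the scatter) is accordingly small. For compound 3 the estimated value is 2.7, and a range of 2.3 to 3 is expected.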

Compound 3, distribution coefficient: 2.7
Compound 3: middle estimate and measured number agree at the digits printed, and the stated range covers the measured number.
By their numbers in this assay, from the lowest: compounds 1, 2 and 3 (each within the scatter of the next).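

In this assay, the carbonyl carbon now has a direct comparison: dimethylamino in place of morpholin-4-yl gives no change at the digits printed from compound 2 to compound 3 (within the scatter), so this read-out does not separate the two groups even though the six-membered non-aromatic ring is gone. The aromatic carbon also has a comparison in one place: methoxy in place of dimethylamino gives a number 0.10 log units higher from compound 1 to compound 3 (within the scatter), and this read-out does not separate those two groups either. No measured evidence bears on why these groups are not separated.

From the compounds shown here alone, each change rests on a single pair, so it remains open whether these results hold on other compounds. Also open, going by these compounds, is how a piperazin-1-yl group or a diethylamino group on the carbonyl carbon, or a chlorine or a carboxylic acid on the aromatic carbon, would read in this assay.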